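The source may hold more compounds than are shown below. What is called first, only, known or untested is meant among the compounds shown, and "the series" means these compounds.

Among the three compounds measured so far in a functional assay on U-251 cells (Homo sapiens) for inhibition, read by sulforhodamine B assay, with a stated time of 48 h (on this read-out lower numbers stand for stronger inhibition of growth and higher numbers for weaker inhibition of growth), compound 1 (`CC1(/C=C/c2ccccc2)C=CC(=O)O1`) has the highest number, at 89800 nM. Placing a trifluoromethyl on its aromatic ring gives compound 2 (`CC1(/C=C/c2ccccc2C(F)(F)F)C=CC(=O)O1`), at 14100 nM, and compound 3 (`CC1(/C=C/c2ccc(C(F)(F)F)cc2)C=CC(=O)O1`), at 15700 nM. These changes amount to a 6.4-fold lower number from compound 1 to compound 2 (0.80 log units; beyond the scatter) and a 5.7-fold lower number from compound 1 to compound 3 (0.76 log units; beyond the scatter), both modest but beyond the scatter.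

Compound 4 (`CC1(/C=C/c2cccc(O)c2)C=CC(=O)O1`) has not yet been measured. It carries hydroxy in place of hydrogen on an aromatic carbon. Among the measured compounds shown here, no measured compound has this group, so the two trifluoromethyl steps offer only indirect guidance. They show that a single group added to that ring of compound 1 can lower the number, but they cannot say how hydroxy will behave. A step in the same direction, smaller than a 5.7-fold lower number from compound 1 to compound 3 (0.76 log units; beyond the scatter), therefore seems the most reasonable expectation, though a step within the scatter remains possible. The expected change is a 2.1-fold lower number from compound 1 to compound 4 (0.33 log units; beyond the scatter). For compound 4 the estimated value is 42000 nM, with an expected range of 14000 nM to 120000 nM.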

Compound 4, concentration for total growth inhibition: 118000 nM
The estimate for compound 4 lay 2.8-fold (0.45 log units) below the measured number; low and high end bracket the measured number.
By their numbers in this assay, from the lowest: compounds 2 and 3 (each within the scatter of the next); then compounds 1 and 4 (each within the scatter of the next).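

In this assay, hydroxy on an aromatic carbon, meta to a group of 9 heavy atoms, gives a 1.3-fold higher number from compound 1 to compound 4 (0.12 log units; within the scatter) and so leaves the number of the parent compound effectively unchanged. The two trifluoromethyl steps alone might have suggested that any single group added to this ring lowers the number, but compound 4 goes against that idea. Nothing measured here explains why hydroxy differs from trifluoromethyl in this way.

The compounds shown do not separate the effect of the group from that of its place on the ring, since none carries trifluoromethyl meta to a group of 9 heavy atoms or hydroxy elsewhere on the ring. On these data alone, how a methoxy group or an amine would behave at this place also remains open.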